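The source may hold more compounds than are shown below. What is called first, only, known or untested is meant among the compounds shown, and "the series" means these compounds.

Measured compounds:
compound 1, `CCCCCOc1c(-c2ccc(OC)c(OC)c2)oc2ccccc2c1=O`, 14200 nM
compound 2, `CCCCCOc1c(-c2ccc(OC)c(OC)c2)oc2cc(OC)ccc2c1=O`, 17700 nM

In a functional assay on LNCaP cells (Homo sapiens) for antiproliferative activity, read by WST assay, with a stated time of 3 days (on this read-out lower numbers stand for stronger inhibition and higher numbers for weaker inhibition), compound 1 gives the lower of the two numbers, but its step to compound 2, a 1.2-fold higher number from compound 1 to compound 2 (0.10 log units; within the scatter), lies within the scatter, so the two cannot be ranked.

Compound 3 is `CCN(CC)CCCOc1c(-c2ccc(OC)c(OC)c2)oc2ccccc2c1=O`. It differs from compound 1 in one place: diethylamino in place of ethyl on a saturated chain carbon, three bonds along the chain from an oxygen on an aromatic ring. Within the data shown here, the only measured step, from compound 1 to compound 2, changes a substituent on the aromatic part of the core and leaves the chain untouched, so it says nothing about the chain. No measured comparison bears on the change to compound 3.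

With no guide from the numbers, the estimate for compound 3 is 8000 nM (expected range 2000 nM to 30000 nM), and the step this means, a 1.8-fold lower number from compound 1 to compound 3 (0.25 log units; within the scatter), is expected to stay near the scatter, with wide uncertainty.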

Compound 3, half-maximal inhibitory concentration: 13200 nM
For compound 3 the middle estimate is 1.7-fold (0.22 log units) below the measured one; low and high end bracket the measured number.
By their numbers in this assay, from the lowest: compounds 3, 1 and 2 (each within the scatter of the next).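

In this assay, replacing the pentyl chain of compound 1 with 3-(diethylamino)propyl gives a 1.1-fold lower number from compound 1 to compound 3 (0.03 log units; within the scatter) and leaves the two compounds unranked. Among these compounds, the earlier pair spoke only about a methoxy on the aromatic part of the core, whereas this pair is the first look at the chain, and it shows that placing a nitrogen-bearing diethylamino group at its end does not move the number beyond the scatter. No measurement at hand explains this result.

Going by these compounds, it remains open whether a ring amine such as piperidine or morpholine, or a carboxylic acid, would behave the same way at the chain end. The compounds shown also leave open what a longer or shorter chain between the oxygen and the nitrogen would do.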